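The source may hold more compounds than are shown below. What is called first, only, known or untested is meant among the compounds shown, and "the series" means these compounds.

Notes on the series sharing the core of compound 1 `O=C(Nc1ccccc1Cl)Nc1nn(-c2ccccc2)c(=O)c2ccccc12`, varied on the amide-type nitrogen. In an assay on CHO cells for displacement of a labelled ligand from adenosine receptor A1 (Homo sapiens), tested at 10 uM (a lower number here means less inhibition, a higher number more inhibition at the concentration tested (going by the name of the read-out)), compound 1 gives 0%. Compound 2 `COc1ccc(NC(=O)Nc2nn(-c3ccccc3)c(=O)c3ccccc23)cc1` gives 4%. Compound 3 `O=C(NCc1ccccc1)Nc1nn(-c2ccccc2)c(=O)c2ccccc12` gives 20%, the highest of the three numbers. The steps of a number 20 percentage points higher from compound 1 to compound 3 (beyond the scatter) and a number 16 percentage points higher from compound 2 to compound 3 (beyond the scatter) show benzyl on the amide-type nitrogen ahead of 2-chlorophenyl or 4-methoxyphenyl, while a number 4 percentage points higher from compound 1 to compound 2 (within the scatter) stays within the scatter. Compound 4 `O=C(Nc1nn(-c2ccccc2)c(=O)c2ccccc12)c1ccco1` differs from compound 3 by furan-2-yl in place of benzylamino on a carbonyl carbon. Among the measured compounds shown here, no measured step touches the carbonyl carbon side, so the benzyl gain seen in a number 20 percentage points higher from compound 1 to compound 3 (beyond the scatter) is taken as given up, and a downward step a number 12 percentage points lower from compound 3 to compound 4 (beyond the scatter) is expected, though loosely. Compound 4 is therefore estimated at 8%, within 0% to 28%.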

Compound 4, a percentage reported as inhibition, at one concentration (the size of the read-out at that concentration, not a potency): 23%
Estimate against measurement, compound 4: 15 percentage points below, and the stated range covers the measured number.
By their numbers in this assay, from the lowest: compounds 1 and 2 (each within the scatter of the next); then compounds 3 and 4 (each within the scatter of the next).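

At this carbonyl carbon, a number 3 percentage points higher from compound 3 to compound 4 (within the scatter) in this assay puts furan-2-yl, with no hydrogen-bond donor, level with benzylamino. Both a number 19 percentage points higher from compound 2 to compound 4 (beyond the scatter) and a number 23 percentage points higher from compound 1 to compound 4 (beyond the scatter) place furan-2-yl, like benzylamino, ahead of (4-methoxyphenyl)amino and (2-chlorophenyl)amino, so among these compounds the higher numbers do not depend on a nitrogen link at the carbonyl carbon. No evidence at hand accounts for these steps.

As far as these compounds go, whether a cyclic amine such as morpholine or a longer alkyl chain on the carbonyl carbon keeps these numbers stays open. Potency also stays open, since each number comes from a single concentration.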